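From a ring to a chain on the hydrazone nitrogen

The source may hold more compounds than are shown below. What is called first, only, known or untested is meant among the compounds shown, and "the series" means these compounds.

Compound 2 `COc1cccc(-c2csc(N/N=C3\CCC(C)C3)n2)c1` gives 1450 nM in an assay on isolated protein for inhibition of Amine oxidase [flavin-containing] A (Homo sapiens), read by fluorescence (on this read-out lower numbers stand for stronger inhibition and higher numbers for weaker inhibition), the lowest of the two numbers seen so far, while compound 1 `COc1cccc(-c2csc(NN=C(C)C)n2)c1` gives 4430 nM in this assay. Compound 3 `CCC(CC)=NNc1nc(-c2cccc(OC)c2)cs1` differs from compound 2 by a group of 6 heavy atoms (5 carbon, 1 nitrogen; no ring) in place of a group of 7 heavy atoms (6 carbon, 1 nitrogen; one five-membered non-aromatic ring of carbon only), on a nitrogen on an aromatic ring. For the measured compounds named here, only one measured step touches this place: a 3.1-fold lower number from compound 1 to compound 2 (0.49 log units; beyond the scatter). Because a 3.1-fold lower number from compound 1 to compound 2 (0.49 log units; beyond the scatter) came with the ring that compound 3 lacks, while compound 3 still carries more of the chain than compound 1, a modest rise is expected, a 1.7-fold higher number from compound 2 to compound 3 (0.24 log units; within the scatter). Compound 3 is therefore estimated at 2500 nM, within 1000 nM to 6500 nM in this assay.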

Compound 3, half-maximal inhibitory concentration: 824 nM
Estimate against measurement, compound 3: 3.0-fold (0.48 log units) above, outside the stated range (below it).
By their numbers in this assay, from the lowest: compounds 3 and 2 (each within the scatter of the next); then compound 1.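

The ring on the nitrogen turns out not to be required in this assay: the open chain of compound 3 in its place gives (a 1.8-fold lower number from compound 2 to compound 3 (0.25 log units; within the scatter)), so the two groups cannot be told apart. The lower number relative to the smaller group of compound 1 thus holds without any ring (a 5.4-fold lower number from compound 1 to compound 3 (0.73 log units; beyond the scatter)). No evidence is at hand that bears on this result. Still open, from the compounds shown here alone, is whether a longer chain, such as two propyl groups, would lower the number further, and whether a six-membered carbon ring or an amine in this group would be tolerated.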